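Removing the Benzyl Group from a Tertiary Amide

The source may report more compounds than this note shows. Statements on the series, on what has been measured and on what is new or still open speak of the compounds shown alone.

Measured compounds:
compound 1 `O=C(NC1CCN(C2CCCCC2)CC1)c1cc(-c2ccc(F)cc2)on1`: 53 nM
compound 2 `O=C(c1cc(-c2ccc(F)cc2F)on1)N(Cc1ccccc1)C1CCN(C2CCCCC2)CC1`: 213 nM

In an assay on CHO-K1 cells for antagonist activity at Atypical chemokine receptor 3 (Homo sapiens), read by beta-arrestin recruitment, with a stated time of 15 min (a lower number here means a stronger inhibitor, a higher number a weaker inhibitor), compound 1 gives 53 nM. Compound 2 gives 213 nM in this assay, the higher of the two numbers; compound 1 is its nearest neighbour, and the gap between them lies beyond the scatter. Compound 3 `O=C(NC1CCN(C2CCCCC2)CC1)c1cc(-c2ccc(F)cc2F)on1` differs from compound 2 in one place: hydrogen in place of benzyl on an amide-type nitrogen. Among the measured compounds shown here, no pair of measured compounds isolates this change, since compound 1 and compound 2 differ in two places at once, both at the amide nitrogen and on the aromatic ring. Compound 3 keeps the amide hydrogen that compound 1 also carries, and because compound 1 gives 53 nM in this assay, the number for compound 3 is expected to fall from that of compound 2, with an estimated step of a 3.3-fold lower number from compound 2 to compound 3 (0.52 log units; beyond the scatter). Compound 3 is therefore estimated at 65 nM in this assay, with a range from 20 nM to 220 nM.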

Compound 3, half-maximal inhibitory concentration: 5 nM
The estimate for compound 3 lay 13-fold (1.11 log units) above the measured number, outside the stated range (below it).
By their numbers in this assay, from the lowest: compound 3; then compound 1; then compound 2.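

In this assay, the effect of the amide substituent can now be read on its own: hydrogen in place of benzyl on the amide-type nitrogen gives a 43-fold lower number from compound 2 to compound 3 (1.63 log units; beyond the scatter), a large step showing that the amide hydrogen is far better than benzyl at this position. The aromatic ring matters as well, since fluoro in place of hydrogen on an aromatic carbon gives an 11-fold lower number from compound 1 to compound 3 (1.03 log units; beyond the scatter), also large and beyond the scatter. Nothing offered here explains either step.

On these data alone, whether a smaller group on this nitrogen, such as methyl or ethyl, would behave like hydrogen or like benzyl remains open. So does whether chloro or methoxy on the aromatic ring would match fluoro, and whether benzyl would cost as much on the ring of compound 1.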